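The source may hold more compounds than are shown below. What is called first, only, known or untested is meant among the compounds shown, and "the series" means these compounds.

Values so far in a functional assay on MCF7 cells (Homo sapiens) for antiproliferative activity, read by MTT assay, with a stated time of 48 h; on this read-out higher numbers stand for weaker inhibition and lower numbers for stronger inhibition
- compound 1 `COc1ccc(-c2c(Nc3cc(OC)c(OC)c(OC)c3)c3ccccc3oc2=O)cc1` gives 82300 nM
- compound 2 `COc1ccc(-c2c(Nc3ccc(F)cc3)c3ccccc3oc2=O)cc1` gives 38500 nM
- compound 3 `COc1ccc(-c2c(Nc3cccc(C(F)(F)F)c3)c3ccccc3oc2=O)cc1` gives 21600 nM

Compound 1 has the highest number of the three, making it the weakest inhibitor here, and its gaps to compound 2 and compound 3 lie beyond the usual scatter. Compound 4 `COc1ccc(-c2c(Nc3cc(OC)c(OC)c(OC)c3)c3ccc(OC)cc3oc2=O)cc1` is compound 1 with methoxy in place of hydrogen on an aromatic carbon of the shared core (methoxy in place of hydrogen on an aromatic carbon). Among the compounds with values here, the only measured step, a 1.8-fold lower number from compound 2 to compound 3 (0.25 log units; within the scatter), concerns the group on nitrogen, not this place. No measurement tests the new methoxy, so no step beyond the scatter is expected in this assay. The expected step is a 1.1-fold lower number from compound 1 to compound 4 (0.04 log units; within the scatter). Compound 4 is estimated at 75000 nM, with an expected range of 30000 nM to 170000 nM.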

Compound 4, half-maximal inhibitory concentration: 89500 nM
For compound 4 the middle estimate is 1.2-fold (0.08 log units) below the measured one, within the range that was stated.
By their numbers in this assay, from the lowest: compounds 3 and 2 (each within the scatter of the next); then compounds 1 and 4 (each within the scatter of the next).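

The earlier compounds shown here differ only in the group on nitrogen, so they say nothing about this aromatic carbon of the shared core. In this assay, adding methoxy there gives a 1.1-fold higher number from compound 1 to compound 4 (0.04 log units; within the scatter), so this single change leaves the number within the scatter, with the group on nitrogen held fixed. Nothing available explains this result.

On these data alone, whether an amine, a carboxylic acid or a longer chain at this carbon would shift the number remains open. So does whether methoxy here would act alike with 4-fluorophenyl on the nitrogen.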